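A few compounds are considered here, and "the series" means these few. Any claim that something is new, unique, unknown or untested is made for them only; others in the source may bear on it.

Of the compounds shown here, two sharing one core have been tested in a functional assay on the whole organism (strain Sprague-Dawley) for inhibition, with Rattus norvegicus as the target, read by paw edema, with stated times of 30 min and 3 h, at a dose of 80 mg/kg by the oral route; a higher number here means more inhibition at the dose given (going by the name of the read-out), a lower number less inhibition. Compound 1 `Cc1nc2ccccc2c(=O)n1NC(=O)NC1CCCCC1` gives 54.8% in this assay. For the measured compounds named here, compound 2 `O=c1c2ccccc2nc(CO[N+](=O)[O-])n1NS(=O)(=O)c1ccccc1` gives 34% in this assay; this is the lower of the two numbers, and the only other compound, compound 1, lies higher by a gap beyond the usual scatter. Compound 3 `Cc1nc2ccccc2c(=O)n1NS(=O)(=O)c1ccccc1` is the next to be measured in this assay. Its structure differs from compound 2 in one place: hydrogen in place of nitrooxy on a saturated chain carbon bound to an aromatic carbon. Going by the values given here, no measured pair in this set differs in a single place, so there is no measured step of this kind to lean on. Compound 2 is expected to move little, with a step of a number 6 percentage points higher from compound 2 to compound 3 (within the scatter) that may stay within the scatter. Compound 3 is estimated at 40% in this assay, with a range from 20% to 60%.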

Compound 3, a percentage reported as inhibition, in the whole organism at one dose (the size of the read-out at that dose, not a potency): 47.8%
Estimate against measurement, compound 3: 7.8 percentage points below, and the stated range covers the measured number.
By their numbers in this assay, from the lowest: compound 2; then compounds 3 and 1 (each within the scatter of the next).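

Nitrooxy and hydrogen on a saturated chain carbon bound to an aromatic carbon are now compared directly for the first time: in this assay the change from (nitrooxy)methyl to methyl gives a number 13.8 percentage points higher from compound 2 to compound 3 (beyond the scatter) and so provides the first step in this set that can be read at a single place. For the compounds shown here, this position is therefore not indifferent to what it carries, and in this pair the compound with nitrooxy is the one with the lower number. Nothing at hand explains the direction of this step.

From the compounds shown here alone, whether an amine, a carboxylic acid or a longer chain such as ethyl at this place would sit nearer compound 2 or compound 3 stays open. Going by these compounds, it is also open whether the same change would give a similar step on compound 1.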